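This account rests on a few compounds, and the source may have more. Where it says the series, first, only, none or still open, it means among the compounds named here.

Three compounds have been measured in a functional assay on HeLa cells (Homo sapiens) for cytotoxicity, read by MTT assay; a higher number here means a weaker inhibitor, a lower number a stronger inhibitor:
Compound 1, `CC(C)=CC[C@@H](OC[C@H](C)O)C1=CC(=O)c2c(O)ccc(O)c2C1=O`, gives 40300 nM.
Compound 2, `COC(C)CO[C@H](CC=C(C)C)C1=CC(=O)c2c(O)ccc(O)c2C1=O`, gives 53400 nM.
Compound 3, `CCCC(O)CC(=O)O[C@H](CC=C(C)C)C1=CC(=O)c2c(O)ccc(O)c2C1=O`, gives 59300 nM.

Compound 2 has the second highest of the three numbers. The steps of a 1.1-fold higher number from compound 2 to compound 3 (0.05 log units; within the scatter) and a 1.3-fold higher number from compound 1 to compound 2 (0.12 log units; within the scatter) both lie within the scatter, so all three compounds sit together rather than apart.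

Compound 4, `CCC(CO[C@H](CC=C(C)C)C1=CC(=O)c2c(O)ccc(O)c2C1=O)OC`, is compound 2 with one change: methyl in place of hydrogen on a saturated chain carbon, two bonds along the chain from an oxygen on a saturated carbon. For the measured compounds named here, no measured step touches this same carbon; the nearest comparisons are the changes to the chain on the oxygen on a saturated carbon, a 1.3-fold higher number from compound 1 to compound 2 (0.12 log units; within the scatter), a 1.5-fold higher number from compound 1 to compound 3 (0.17 log units; within the scatter) and a 1.1-fold higher number from compound 2 to compound 3 (0.05 log units; within the scatter), all within the scatter. A single added methyl is a smaller change than any of those, so no step beyond the scatter is expected in this assay. The expected step is a 1.0-fold higher number from compound 2 to compound 4 (0.01 log units; within the scatter). Compound 4 is therefore estimated at 55000 nM, within 25000 nM to 120000 nM.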

Compound 4, half-maximal inhibitory concentration: 63500 nM
For compound 4 the middle estimate is 1.2-fold (0.06 log units) below the measured one, within the range that was stated.
By their numbers in this assay, from the lowest: compounds 1, 2, 3 and 4 (each within the scatter of the next).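

In this assay the change from 2-methoxypropyl to 2-methoxybutyl gives a 1.2-fold higher number from compound 2 to compound 4 (0.08 log units; within the scatter) and so stays inside the scatter, which means that this saturated chain carbon takes a methyl in place of hydrogen without a readable shift. The wider comparisons, a 1.1-fold higher number from compound 3 to compound 4 (0.03 log units; within the scatter) and a 1.6-fold higher number from compound 1 to compound 4 (0.20 log units; within the scatter), also stay inside the scatter, so all four compounds still sit together. Nothing measured here explains why these numbers stay so close.

The compounds shown leave open whether an amine, a carboxylic acid or a much longer chain at this carbon would give a step beyond the scatter.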